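Moving the Chlorine on the Benzoyl Group

The source may report more compounds than this note shows. Statements on the series, on what has been measured and on what is new or still open speak of the compounds shown alone.

Measured compounds:
compound 1 `O=C(Nc1ccccc1C(F)(F)F)C1CCc2ccccc2N1C(=O)c1cccc(Cl)c1`: 797 nM
compound 2 `COc1ccc(NC(=O)C2CCc3ccccc3N2)cc1`: 50200 nM
compound 3 `O=C(Nc1cc(C(F)(F)F)cc(C(F)(F)F)c1)C1CCc2ccccc2N1C(=O)c1ccccc1`: 3540 nM

In a functional assay on HCT-15 cells (Homo sapiens) for cytotoxicity, read by sulforhodamine B assay, with a stated time of 72 h (a lower number here means a stronger inhibitor of growth, a higher number a weaker inhibitor of growth), compound 1 gives the lowest number of the three. Compound 3 sits above it by a margin beyond the usual scatter, and compound 2 sits further above still. Neither compound 2 nor compound 3 differs from compound 1 in only one place, so no single structural step can be read off between any two of the measured compounds; the numbers only show that compound 1 is the strongest growth inhibitor among them.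

The unmeasured compound 4 `O=C(Nc1ccccc1C(F)(F)F)C1CCc2ccccc2N1C(=O)c1ccc(Cl)cc1` differs from compound 1 in one place only: 4-chlorophenyl in place of 3-chlorophenyl on a carbonyl carbon. The atoms are the same and only the point at which the chlorine sits on that ring moves. Among the measured compounds shown here, nothing among the measured compounds tells how this assay responds to such a shift, so the expectation rests on the change being small in size. A step of modest size, in either direction or none beyond the scatter, is the most likely outcome, with a slight lean towards a weaker inhibitor. Compound 4 is therefore estimated at 1100 nM, within a range from 350 nM to 3500 nM, which means an expected step of a 1.4-fold higher number from compound 1 to compound 4 (0.14 log units; within the scatter).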

Compound 4, concentration for 50% growth inhibition: 839 nM
For compound 4 the middle estimate is 1.3-fold (0.12 log units) above the measured one; the measured number falls inside the stated range.
By their numbers in this assay, from the lowest: compounds 1 and 4 (each within the scatter of the next); then compound 3; then compound 2.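

Among the compounds shown here, replacing 3-chlorophenyl with 4-chlorophenyl on the carbonyl carbon gives a 1.1-fold higher number from compound 1 to compound 4 (0.02 log units; within the scatter) in this assay and provides the first direct comparison in this set. Unlike the earlier compounds, this matched pair isolates a single change, and it shows that moving the chlorine between these two points on the ring does not produce a measurable difference in growth inhibition beyond the usual scatter between repeat measurements. The data at hand offer no independent measurement that could explain this result.

For the compounds shown here, compound 2 and compound 3 each differ from compound 1 and compound 4 in more than one place, so no step involving them can be read, and the effect of removing the chlorine from the ring remains unknown. Going by these compounds, it also remains open how this assay would respond if an amine or a carboxylic acid took the place of the chlorine on this ring, or whether the flat result seen for this one shift would hold for such groups.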